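A Further Methoxy on the Aryl Ketone of Compound 1

This account rests on a few compounds, and the source may have more. Where it says the series, first, only, none or still open, it means among the compounds named here.

Compound 1 `COc1ccc(C(=O)/C=C/c2cc(-c3cc(OC)c(OC)c(OC)c3)n[nH]2)cc1OC` gives 7820 nM in a functional assay on SK-OV-3 cells (Homo sapiens) for inhibition, read by sulforhodamine B assay, with a stated time of 48 h (on this read-out higher numbers stand for weaker inhibition of growth and lower numbers for stronger inhibition of growth), and holds the lowest number among the three measured compounds. Compound 2 `COc1ccc(C(=O)/C=C/c2cc(-c3cc(OC)c(OC)c(OC)c3)n[nH]2)cc1` gives 20500 nM in this assay, and compound 3 `COc1cc(-c2cc(/C=C/C(=O)c3ccc(F)c(F)c3)[nH]n2)cc(OC)c1OC` gives 58600 nM in this assay. Compound 4 `COc1cc(C(=O)/C=C/c2cc(-c3cc(OC)c(OC)c(OC)c3)n[nH]2)cc(OC)c1OC` has not yet been measured; it differs from compound 1 by methoxy in place of hydrogen on an aromatic carbon. The most closely related measured step is a 2.6-fold higher number from compound 1 to compound 2 (0.42 log units; beyond the scatter), in which taking a methoxy off the ring on the carbonyl carbon gave the higher number. The steps of a 7.5-fold higher number from compound 1 to compound 3 (0.87 log units; beyond the scatter) and a 2.9-fold higher number from compound 2 to compound 3 (0.46 log units; beyond the scatter) show that replacing that methoxy-bearing ring with a fluorinated one raises the number further. For the measured compounds named here, all measured changes on this ring removed methoxy and gave higher numbers, and no measured step adds one. Compound 4 is expected to give a somewhat lower number or one within the scatter of compound 1, because the reverse change gave a 2.6-fold higher number from compound 1 to compound 2 (0.42 log units; beyond the scatter). Compound 4 is thus estimated at 5000 nM, within a range from 1800 nM to 14000 nM. The expected step is a 1.6-fold lower number from compound 1 to compound 4 (0.19 log units; within the scatter).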

Compound 4, concentration for total growth inhibition: 11100 nM
Beside the measured number, compound 4's estimate is 2.2-fold (0.35 log units) below it, and the stated range covers the measured number.
By their numbers in this assay, from the lowest: compounds 1, 4 and 2 (each within the scatter of the next, the first and the last beyond it); then compound 3.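

The added methoxy, ortho to a methoxy group and meta to a large group on the aryl ketone ring, gives a 1.4-fold higher number from compound 1 to compound 4 (0.15 log units; within the scatter) in this assay. For the compounds shown here, the earlier compounds showed only methoxy being taken off or the ring being replaced, and each of those steps lay beyond the scatter, such as a 2.6-fold higher number from compound 1 to compound 2 (0.42 log units; beyond the scatter); this is the first step that adds a methoxy, and it leaves compound 4 indistinguishable from compound 1 on this read-out. No measurement available here explains this result.

The compounds shown leave open whether a different group at this position, such as a hydroxyl, an amine or a longer alkoxy chain, would also leave the number within the scatter of compound 1. They also leave open whether a single fluorine there would do so.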